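This account rests on a few compounds, and the source may have more. Where it says the series, first, only, none or still open, it means among the compounds named here.

In an ADME assay on microsomes from liver (Rattus norvegicus) for metabolic stability (a higher number here means that the compound lasts longer, a lower number that the compound disappears faster), three compounds have been measured so far. Compound 1 `CCC(CC)(c1nnc[nH]1)c1ccc(-c2ccc3cc(F)cc(F)c3c2)[nH]c1=O` gives 1.26 h and compound 2 `CC(C)C(Nc1nnc[nH]1)c1ccc(-c2ccc3cccc(F)c3c2)[nH]c1=O` gives 1.29 h, so these two values lie within the usual scatter of each other. Compound 3 `CCn1ncc2c(F)cc(-c3ccc(C(CC)(CC)c4nnc(C)[nH]4)c(=O)[nH]3)cc21` gives > 3 h, which is a limit of the assay and not a number. Compound 2 therefore stands level with compound 1, and its value offers the only direct starting point for what follows.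

Compound 4 `CC(C)C(c1cnc(N)s1)c1ccc(-c2ccc3cccc(F)c3c2)[nH]c1=O` departs from compound 2 in a single place: 2-amino-1,3-thiazol-5-yl in place of (4H-1,2,4-triazol-3-yl)amino on a saturated chain carbon bound to an aromatic carbon and a saturated chain carbon. In words, 2-amino-1,3-thiazol-5-yl comes in place of (4H-1,2,4-triazol-3-yl)amino on a saturated chain carbon bound to an aromatic carbon and a saturated chain carbon. The rest of the structure stays the same. Among the compounds with values here, no measured pair of compounds differs in one place only, so the data offer no direct precedent for this exchange, and any expectation for this assay remains tentative. The expected step is a 1.3-fold lower number from compound 2 to compound 4 (0.11 log units; within the scatter), a small fall that may well stay within the scatter. For compound 4 the estimated half-life is 1 h, with an expected range from 0.4 h to 2.4 h.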

Compound 4, half-life: 0.0983 h
The estimate for compound 4 lay 10-fold (1.01 log units) above the measured number; the measured number lies below the stated range.
By their numbers in this assay, from the lowest: compound 4; then compounds 1 and 2 (each within the scatter of the next). At a limit, above all of these: compound 3.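

In this assay, the exchange of (4H-1,2,4-triazol-3-yl)amino for 2-amino-1,3-thiazol-5-yl on a saturated chain carbon bound to an aromatic carbon and a saturated chain carbon gives a 13-fold lower number from compound 2 to compound 4 (1.12 log units; beyond the scatter), a large step beyond the scatter. Within the data shown here, this is the only step between compounds differing in one place, and it shows that the group at this position can strongly change the half-life even though the two groups have the same count of heavy atoms and the rest of the structure stays the same. No measurement shown here bears on why the number falls so far, so the step stands without an explanation.

On these data alone, it remains open whether the fall belongs to the 2-amino-1,3-thiazol-5-yl group as a whole or to its amino group, which a methyl group or an acetamide at that point could help to separate. As far as these compounds go, it is also open whether the same exchange would give a step of similar size on the core of compound 1, where the group sits on a carbon bearing two ethyl groups.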